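Fluorinated benzyl indole diketo esters: MT4 cytotoxicity notes

The source may report more compounds than this note shows. Statements on the series, on what has been measured and on what is new or still open speak of the compounds shown alone.

Measured so far:
compound 1 `COc1cccc2c1c(C(=O)/C=C(\O)C(=O)O)cn2Cc1ccc(F)c(F)c1` — 71000 nM
compound 2 `CCOC(=O)/C(O)=C/C(=O)c1cn(Cc2cc(F)c(F)c(F)c2)c2cccc(OC)c12` — 33400 nM

In an ADME assay on MT4 cells (Homo sapiens) for cytotoxicity, read by MTT assay (a higher number here means that more compound is tolerated, a lower number that less compound is tolerated), compound 1 gives 71000 nM and compound 2 gives 33400 nM. Compound 2 thus stands at the lower of the two numbers, and its gap to compound 1 lies beyond the usual scatter. Among the measured compounds shown here, compound 1 and compound 2 differ in more than one place, so the two values show only that compound 2 is tolerated less well.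

Compound 3 `CCOC(=O)/C(O)=C/C(=O)c1cn(Cc2ccc(F)c(F)c2)c2cccc(OC)c12` follows from compound 2 by a single change: hydrogen in place of fluoro on an aromatic carbon. For the measured compounds named here, no measured pair shows this change by itself. The step from compound 2 to compound 3 is expected to be small, most likely toward a higher number or none beyond the scatter, with some support in that compound 1, which also carries the 3,4-difluorobenzyl group, gives 71000 nM. For compound 3 the estimated value in this assay is 45000 nM, within a range of 20000 nM to 100000 nM, an expected step of a 1.3-fold higher number from compound 2 to compound 3 (0.13 log units; within the scatter).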

Compound 3, half-maximal cytotoxic concentration: 125000 nM
Compound 3: middle estimate off by 2.8-fold (0.44 log units), on the low side; measured number outside the range, above it.
By their numbers in this assay, from the lowest: compound 2; then compounds 1 and 3 (each within the scatter of the next).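

Among the compounds shown here, the first one-place pair shows that, in this assay, the change from 3,4,5-trifluorobenzyl to 3,4-difluorobenzyl is not silent: hydrogen in place of fluoro on this aromatic carbon gives a 3.7-fold higher number from compound 2 to compound 3 (0.57 log units; beyond the scatter). In this single pair, the fluoro group at this position goes with less compound being tolerated, which the earlier two compounds, differing in more than one place, could not isolate. With the 3,4-difluorobenzyl group held fixed, ethyl in place of hydrogen on an oxygen next to a carbonyl group gives a 1.8-fold higher number from compound 1 to compound 3 (0.25 log units; within the scatter), so this change does not separate the two compounds.

As far as these compounds go, whether the step belongs to fluoro itself or to any group on this carbon remains open, and a chlorine, a methyl or a methoxy group there would tell these apart. Also open, from the compounds shown here alone, is whether the step carries over to the free carboxylic acid, or to an amide in place of the ethyl ester. The data at hand offer no measurement that bears on the reason for the step at this position.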